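This account rests on a few compounds, and the source may have more. Where it says the series, first, only, none or still open, it means among the compounds named here.

Measured compounds:
Compound 1, `CCCNS(=O)(=O)c1ccc(Nc2ncc3c(n2)N(C2CCCC2)[C@H](CC)C(=O)N3C)cc1` — 563 nM
Compound 2, `CCC1C(=O)N(C)c2cnc(Nc3ccc(S(=O)(=O)NCCCO)cc3)nc2N1c1ccn(C)n1` — 48900 nM

Both compounds were tested in a functional assay on A549 cells (Homo sapiens) for antiproliferative activity, read by CCK-8 assay, with a stated time of 72 h; a higher number here means a weaker inhibitor of growth, a lower number a stronger inhibitor of growth. Compound 1 gives 563 nM. Compound 2 gives 48900 nM, the higher of the two numbers, and the gap between the two lies far beyond the usual scatter of repeated measurements, so compound 2 is clearly the weaker growth inhibitor of the pair. The two compounds differ in several places at once, so no single structural change can be tied to this gap.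

Compound 3, `CCC1C(=O)N(C)c2cnc(Nc3ccc(S(=O)(=O)NCCO)cc3)nc2N1c1ccn(C)n1`, is not yet measured. It differs from compound 2 in one place: hydroxy in place of hydroxymethyl on a saturated chain carbon, two bonds along the chain from a sulfonamide nitrogen. In other words, the 3-hydroxypropyl group on the sulfonamide nitrogen becomes a 2-hydroxyethyl group, one chain carbon shorter. For the measured compounds named here, no measured pair here shows a change of this kind, so there is nothing to lean on for its direction. A shortening of a chain by a single carbon, with the same hydroxy end kept, is expected to move this assay little, if at all, beyond the scatter. The expected step from compound 2 to compound 3 in this assay is therefore a 1.2-fold lower number from compound 2 to compound 3 (0.09 log units; within the scatter). Compound 3 is estimated to give 40000 nM in this assay. For compound 3 the estimate is expected to fall between 15000 nM and 110000 nM.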

Compound 3, concentration for 50% growth inhibition: "not active" (no number reported)
For compound 3 the study gives words and no number, so the estimate cannot be set against anything.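

For the compounds shown here, for compound 3, this assay gives the words "not active" and no number, so no step from compound 2 to compound 3 can be read. No evidence on the cause is available here. The compounds shown leave open how shortening the 3-hydroxypropyl group to 2-hydroxyethyl changes growth inhibition.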